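Amide substituent variation at the carboxamide of the shared core

The source may hold more compounds than are shown below. What is called first, only, known or untested is meant among the compounds shown, and "the series" means these compounds.

Measured so far:
compound 1 `CCn1c(C(=O)N[C@@H](C)C(=O)OC)ccc1C(CC)(CC)c1ccc(OCS(=O)(=O)c2ccccc2)c(C)c1` — 43700 nM
compound 2 `CCn1c(C(=O)NCCO)ccc1C(CC)(CC)c1ccc(OCS(=O)(=O)c2ccccc2)c(C)c1` — 15500 nM

Both compounds were read in a functional assay on MCF7 cells (Homo sapiens) for antiproliferative activity, read by MTT assay, with a stated time of 24 h; on this read-out lower numbers stand for stronger inhibition and higher numbers for weaker inhibition. Among the compounds with values here, compound 2 holds the lowest number of the two; its nearest neighbour is compound 1, and the step of a 2.8-fold lower number from compound 1 to compound 2 (0.45 log units; beyond the scatter) is the only measured step in the set. That step changed the substituent on the amide-type nitrogen and is the single point of reference for what follows.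

Compound 3 `CCn1c(C(=O)N[C@@H](CO)C(C)C)ccc1C(CC)(CC)c1ccc(OCS(=O)(=O)c2ccccc2)c(C)c1` has not yet been measured. It differs from compound 2 by isopropyl in place of hydrogen on a saturated chain carbon bound to an amide-type nitrogen and a saturated chain carbon. The change is located on the same amide-type substituent as the measured step, but the measured step exchanged a whole group rather than adding a branch at the carbon bound to the amide-type nitrogen, so it bears on the new step only loosely and its size cannot be transferred directly. Within the data shown here, with no closer precedent, a step in this assay near or within the scatter is expected, leaning toward a slightly higher number. Compound 3 is therefore estimated at 20000 nM, within 8000 nM to 50000 nM, an expected step of a 1.3-fold higher number from compound 2 to compound 3 (0.11 log units; within the scatter).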

Compound 3, half-maximal inhibitory concentration: 18800 nM
The estimate for compound 3 lay 1.1-fold (0.03 log units) above the measured number; measured number inside the range.
By their numbers in this assay, from the lowest: compounds 2 and 3 (each within the scatter of the next); then compound 1.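

In this assay, isopropyl in place of hydrogen on the saturated chain carbon bound to the amide-type nitrogen gives a 1.2-fold higher number from compound 2 to compound 3 (0.08 log units; within the scatter), so this branch adds no step beyond the scatter to the 2-hydroxyethyl substituent. Exchanging the whole substituent, 1-(hydroxymethyl)-2-methylpropyl in place of 1-(methoxycarbonyl)ethyl, gives a 2.3-fold lower number from compound 1 to compound 3 (0.37 log units; beyond the scatter), a second step beyond the scatter away from compound 1, and no compound shown goes against this separation of the two hydroxyl-bearing substituents from the methoxycarbonyl one. No data on hand give a reason for either step.

Still open, as far as these compounds go, is whether a carboxylic acid in place of the methoxycarbonyl group of compound 1, or an amine in place of the hydroxyl of compound 2, would shift the number in this assay. Also open, from the compounds shown here alone, is whether a longer chain or a phenyl group in place of the isopropyl of compound 3 would stay within the scatter of compound 3.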